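The compounds below may be only part of what the source reports. "The series", "measured", "known", "first", "only" and "open" are said of these compounds alone.

In a functional assay on cells (Homo sapiens) for inhibition, read by MTT assay, with a stated time of 72 h (on this read-out higher numbers stand for weaker inhibition and lower numbers for stronger inhibition), compound 2 `CC(=O)Nc1ccc(Nc2ncnc3c2cnn3CC(=O)O)cc1` has no exact number and gives only a limit of > 64 ug/mL. Compound 3 `O=C(O)Cn1ncc2c(Nc3ccc(NS(=O)(=O)c4ccccc4)cc3)ncnc21` carries phenylsulfonyl in place of acetyl on a nitrogen on an aromatic ring, a change counted as phenylsulfonyl in place of acetyl on a nitrogen on an aromatic ring. For the measured compounds named here, no measured step shows what such a swap does. The closest guide is compound 1 `O=C(O)Cn1ncc2c(Nc3ccc(NS(=O)(=O)c4ccc([N+](=O)[O-])cc4)cc3)ncnc21`, which carries a nitro-bearing phenylsulfonyl and also gives only a limit, > 100 ug/mL. The expected step that the limit leaves unreadable from compound 2 to compound 3 is therefore small, towards weaker inhibition and within the usual scatter. For compound 3 the estimated value is 100 ug/mL, with an expected range from 50 ug/mL to 200 ug/mL.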

Compound 3, half-maximal inhibitory concentration: > 100 ug/mL
Compound 3: no number, only a limit (the forecaster's own chance of this, stated with the estimate: 65%); the middle value lies on the limit itself.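

For the compounds shown here, compound 3, like compound 1 and compound 2, gives only a limit in this assay, so no step from either of them to compound 3 can be read. The compounds shown leave open what exact value each compound has, and what swapping acetyl for phenylsulfonyl or removing nitro does.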